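A few compounds are considered here, and "the series" means these few. Any claim that something is new, unique, unknown or untested is made for them only; others in the source may bear on it.

Measured in a functional assay on HeLa cells (Homo sapiens) for antiproliferative activity, read by spectrophotometry, with a stated time of 2 days; on this read-out lower numbers stand for stronger inhibition of growth and higher numbers for weaker inhibition of growth:

- Compound 1 `COc1ccc(C(F)(F)F)cc1Nc1ncc(C(F)(F)F)c(N2Cc3cccc(N(C)S(C)(=O)=O)c3C2)n1`: 17200 nM
- Compound 2 `CN(c1cccc2c1CN(c1nc(Nc3ccc(Nc4ccccc4)cc3)ncc1C(F)(F)F)C2)S(C)(=O)=O`: 7300 nM

Compound 1 stands at the higher of these two numbers, so it is the weaker growth inhibitor of the pair, and the gap to compound 2 lies beyond the usual scatter.

Compound 3 `Cc1ccc(Nc2ncc(C(F)(F)F)c(N3Cc4cccc(N(C)S(C)(=O)=O)c4C3)n2)c(C)c1` has not yet been measured. It keeps the core of compound 1 and changes one group: 2,4-dimethylphenyl in place of 2-methoxy-5-(trifluoromethyl)phenyl on a nitrogen on an aromatic ring.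

Within the data shown here, no measured pair of compounds differs in just one place, so there is no direct guide to the effect of this swap in this assay. Among the measured compounds shown here, the only reference is the span of the two known numbers, from compound 2 at 7300 nM to compound 1 at 17200 nM. A modest move toward a lower number is expected, most likely not beyond the scatter. The expected change is a 1.4-fold lower number from compound 1 to compound 3 (0.16 log units; within the scatter). For compound 3 the estimated value is 12000 nM, with an expected range from 5000 nM to 28000 nM.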

Compound 3, concentration for 50% growth inhibition: 10600 nM
For compound 3 the middle estimate is 1.1-fold (0.05 log units) above the measured one; the measured number falls inside the stated range.
By their numbers in this assay, from the lowest: compounds 2, 3 and 1 (each within the scatter of the next, the first and the last beyond it).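

Among these compounds, this is the first step read at this place, on a nitrogen on an aromatic ring, and it is read in this assay: 2,4-dimethylphenyl in place of 2-methoxy-5-(trifluoromethyl)phenyl gives a 1.6-fold lower number from compound 1 to compound 3 (0.21 log units; within the scatter), so the two compounds cannot be told apart. The swap is not a small one on paper, since the group that leaves holds oxygen and fluorine and the group that enters holds only carbon and has fewer heavy atoms, yet growth inhibition in this read-out stays at the same level, so here neither the methoxy nor the trifluoromethyl group shows up as needed for the measured activity. No other data bear on why the number holds, so the result stands without an explanation.

As far as these compounds go, both ring groups of compound 1 left in one step and two methyl groups came in, so the share of each single group stays unknown, and opposing effects of separate groups cannot be ruled out. From the compounds shown here alone, it also stays open whether a quite different group on this ring, such as an amine or a carboxylic acid, would move the number beyond the scatter.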